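A few compounds are considered here, and "the series" means these few. Any claim that something is new, unique, unknown or untested is made for them only; others in the source may bear on it.

Measured in a functional assay on MDA-MB-231 cells (Homo sapiens) for antiproliferative activity, read by MTT assay, with a stated time of 24 h; a higher number here means a weaker inhibitor, a lower number a stronger inhibitor:

- Compound 1 `O=C(O)CC(NS(=O)(=O)c1ccc(F)cc1)c1ccccc1`: 88400 nM
- Compound 2 `O=C(O)CC(NS(=O)(=O)c1ccc(C(F)(F)F)cc1)c1ccccc1`: 56100 nM
- Compound 3 `CC(C)(C)c1ccc(C(CC(=O)O)NS(=O)(=O)c2ccc(C(F)(F)F)cc2)cc1`: 53700 nM

Among these three, compound 2 gives 56100 nM, and its steps to compound 1 and to compound 3 both lie within the scatter. The unmeasured compound 4 `O=C(O)CC(NS(=O)(=O)c1ccc(C(F)(F)F)cc1)c1ccccc1F` differs from compound 2 in one place: fluoro in place of hydrogen on an aromatic carbon. This is fluoro in place of hydrogen on an aromatic carbon, so that phenyl becomes 2-fluorophenyl.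

Within the data shown here, no measured step makes this exact change, but two bear on it. The closer precedent is a 1.0-fold lower number from compound 2 to compound 3 (0.02 log units; within the scatter), which also replaces hydrogen on an aromatic carbon, there with tert-butyl. The other is a 1.6-fold lower number from compound 1 to compound 2 (0.20 log units; within the scatter), which puts trifluoromethyl in place of fluoro. Neither step leaves the scatter, so no step beyond the scatter is expected in this assay, and the data suggest no direction. The expected change is a 1.1-fold lower number from compound 2 to compound 4 (0.03 log units; within the scatter), which would remain within the scatter. For compound 4 the estimated value is 52000 nM, with an expected range from 26000 nM to 100000 nM.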

Compound 4, half-maximal inhibitory concentration: 47100 nM
The estimate for compound 4 lay 1.1-fold (0.04 log units) above the measured number; the range from low to high includes it.
By their numbers in this assay, from the lowest: compounds 4, 3, 2 and 1 (each within the scatter of the next).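

In this assay, turning phenyl into 2-fluorophenyl gives a 1.2-fold lower number from compound 2 to compound 4 (0.08 log units; within the scatter), which shows that a single fluorine on this aromatic carbon, ortho to a large group, stays within the scatter of the hydrogen compound. Read with a 1.0-fold lower number from compound 2 to compound 3 (0.02 log units; within the scatter), it extends what was seen with tert-butyl: on this ring, both a group of one heavy atom and the much larger tert-butyl now give steps from compound 2 that remain within the scatter, and neither step gives a direction for substitution on this ring. No measurement is available that would account for this result.

The compounds shown leave open whether a group other than fluoro at this same place, such as an amine, a methoxy group or a hydroxyl group, would give a step beyond the scatter. They also leave open whether replacing the carboxylic acid with a methyl ester or a primary amide, or extending the acid-bearing chain by a longer chain, would move the number further than any ring substitution shown here.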